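Adding hydroxymethyl to the pyrrolidin-1-yl group of compound 3

The source may report more compounds than this note shows. Statements on the series, on what has been measured and on what is new or still open speak of the compounds shown alone.

In a functional assay on Caco-2 cells (Homo sapiens) for inhibition, read by MTT assay, with a stated time of 48 h, tested at 10 uM (a higher number here means more inhibition of growth at the concentration tested, a lower number less inhibition of growth), compound 3 `Cc1cc(=O)c2c(O)c(CN3CCCC3)c(O)c([C@H]3CCN(C)C[C@H]3O)c2o1` gives 22%. Compound 2 `CCN(CC)Cc1c(O)c([C@H]2CCN(C)C[C@H]2O)c2oc(C)cc(=O)c2c1O` gives 17%. The gap between compound 2 and compound 3 lies within the scatter. Compound 1 `COc1ccc(COc2cc(O)c3c(=O)cc(C)oc3c2[C@H]2CCN(C)C[C@H]2O)cc1` gives 8%. The gap between compound 1 and compound 3 lies beyond the scatter. Compound 4 `Cc1cc(=O)c2c(O)c(CN3CCCC3CO)c(O)c([C@H]3CCN(C)C[C@H]3O)c2o1` has hydroxymethyl in place of hydrogen on a saturated ring carbon, next to the ring nitrogen: hydroxymethyl in place of hydrogen on a saturated ring carbon. For the measured compounds named here, the only measured step that bears on this change is pyrrolidin-1-yl in place of diethylamino, a number 5 percentage points higher from compound 2 to compound 3 (within the scatter). Going by the values given here, no measured compound carries hydroxymethyl, so no direct precedent exists, and no shift beyond the scatter is expected in this assay. The estimated step is a number 2 percentage points lower from compound 3 to compound 4 (within the scatter). Compound 4 is expected at 20%, with an estimated range of 9% to 34%.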

Compound 4, percent growth inhibition at one concentration: 19%
For compound 4 the middle estimate is 1 percentage points above the measured one; the range from low to high includes it.
By their numbers in this assay, from the lowest: compounds 1, 2, 4 and 3 (each within the scatter of the next, the first and the last beyond it).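

For the compounds shown here, on the saturated ring carbon next to the ring nitrogen, hydroxymethyl in place of hydrogen gives a number 3 percentage points lower from compound 3 to compound 4 (within the scatter) in this assay, the first reading of a substituent on this ring. Against the open-chain amine, 2-(hydroxymethyl)pyrrolidin-1-yl in place of diethylamino gives a number 2 percentage points higher from compound 2 to compound 4 (within the scatter), so neither step separates the three amines. Nothing available accounts for these steps. On these data alone, whether a carboxylic acid, a primary amine or a longer hydroxyalkyl chain on this ring carbon would move the number beyond the scatter remains open.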